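Swapping a ketone partner for an anilide

The source may report more compounds than this note shows. Statements on the series, on what has been measured and on what is new or still open speak of the compounds shown alone.

Compound 2 `O=C(CSc1nncnc1-c1ccccc1Cl)c1ccc(Cl)c(Cl)c1` and compound 1 `O=C(CSc1nncnc1-c1cccc2ccccc12)Nc1ccccc1Br` share a core and were both tested in an ADME assay on MT4 cells (Homo sapiens) for cytotoxicity, read by MTT assay; a higher number here means that more compound is tolerated, a lower number that less compound is tolerated. Compound 1 gives 87000 nM there, while compound 2 gives 33000 nM, the lowest of the two numbers; the gap between them lies beyond the usual scatter, so compound 2 is the less tolerated of the pair. Compound 3 `Cc1ccccc1NC(=O)CSc1nncnc1-c1ccccc1Cl` has not yet been measured. It differs from compound 2 in one place: (2-methylphenyl)amino in place of 3,4-dichlorophenyl on a carbonyl carbon. Compound 3 thereby carries an anilide of the same kind as compound 1, which gives 87000 nM, so the change is expected to move the number upward, with a 2.1-fold higher number from compound 2 to compound 3 (0.33 log units; beyond the scatter) as the estimated step. For compound 3 the expected value in this assay is 70000 nM, likely within 30000 nM to 160000 nM.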

Compound 3, half-maximal cytotoxic concentration: 142000 nM
Estimate against measurement, compound 3: 2.0-fold (0.31 log units) below, within the range that was stated.
By their numbers in this assay, from the lowest: compound 2; then compounds 1 and 3 (each within the scatter of the next).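

On the carbonyl carbon, exchanging 3,4-dichlorophenyl for (2-methylphenyl)amino brings a 4.3-fold higher number from compound 2 to compound 3 (0.63 log units; beyond the scatter) in this assay, so a change at this one place is enough to alter how much compound the cells tolerate. Going by these compounds alone, compounds 1 and 2 differ in more than one place, so this pair is the first to isolate this position: the heavy-atom count stays the same, the chlorine atoms leave, and a nitrogen with a hydrogen-bond donor enters. Nothing measured here explains the rise.

The exchange alters the ring's substituents and the atom joining that ring to the carbonyl together, so their separate contributions cannot be told apart. From the compounds shown here alone, a 3,4-dichlorophenylamino group or an unsubstituted phenylamino group on the same carbonyl carbon would bear on that question, and their effects remain open.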